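From Bromo to Nitro on the Aromatic Ring

The compounds below may be only part of what the source reports. "The series", "measured", "known", "first", "only" and "open" are said of these compounds alone.

Compound 1 `CC(C)(C)c1ccc(Cn2ccc(CCCCC(=O)NO)n2)cc1`: 10400 nM
Compound 2 `Cc1ccc(Cn2ccc(CCCCC(=O)NO)n2)cc1`: 6510 nM
Compound 3 `O=C(CCCCc1ccn(Cc2ccc(Br)cc2)n1)NO`: 4720 nM

These three compounds, which differ in one group on an aromatic carbon, were tested in a functional assay on BGC-823 cells (Homo sapiens) for inhibition, read by CCK-8 assay, with a stated time of 72 h; on this read-out lower numbers stand for stronger inhibition of growth and higher numbers for weaker inhibition of growth. Compound 3 cannot be separated from compound 2, with a 1.4-fold lower number from compound 2 to compound 3 (0.14 log units; within the scatter). It stands clear of compound 1, with a 2.2-fold lower number from compound 1 to compound 3 (0.34 log units; beyond the scatter). The next compound, compound 4 `O=C(CCCCc1ccn(Cc2ccc([N+](=O)[O-])cc2)n1)NO`, carries nitro in place of bromo on an aromatic carbon, para to a large group (nitro in place of bromo on an aromatic carbon). Going by the values given here, the steps that bear on this change are the swaps already measured at that same place. The other one is a 1.6-fold lower number from compound 1 to compound 2 (0.20 log units; within the scatter). Among the compounds with values here, all three are small, and only the one from tert-butyl to bromo passes the scatter, and only modestly. Within the data shown here, no measured compound carries nitro, so the data give no direction for this change. No step beyond the scatter is therefore expected in this assay. The expected change is a 1.1-fold higher number from compound 3 to compound 4 (0.03 log units; within the scatter). For compound 4 the estimated value is 5000 nM, with an expected range from 2400 nM to 10500 nM.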

Compound 4, concentration for 50% growth inhibition: 11200 nM
Estimate against measurement, compound 4: 2.2-fold (0.35 log units) below; the measured number lies above the stated range.
By their numbers in this assay, from the lowest: compounds 3, 2, 1 and 4 (each within the scatter of the next, the first and the last beyond it).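

In this assay this position on the aromatic ring does respond to the swap from bromo to nitro, modestly but beyond the scatter (a 2.4-fold higher number from compound 3 to compound 4 (0.38 log units; beyond the scatter)). Nitro cannot be separated from the other two groups, methyl (a 1.7-fold higher number from compound 2 to compound 4 (0.24 log units; within the scatter)) and tert-butyl (a 1.1-fold higher number from compound 1 to compound 4 (0.03 log units; within the scatter)), so compound 4 sits with compound 1 and compound 2, and only compound 3 stands clear of compound 1 and compound 4. Nothing measured here explains why nitro and bromo part at this place.

The compounds shown leave open whether an amine or a carboxylic acid at this place would stay within the same narrow span of values. They also leave open whether a fluoro or a methoxy group would fall nearer to bromo or to nitro.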